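The source may report more compounds than this note shows. Statements on the series, on what has been measured and on what is new or still open speak of the compounds shown alone.

Measured in a functional assay on RAW264.7 cells (Mus musculus) for inhibition, read by Griess assay, with a stated time of 24 h; on this read-out higher numbers stand for weaker inhibition and lower numbers for stronger inhibition:

- compound 1 `CC(=O)S[C@@]12CC[C@H](O)[C@@H]1C(=O)NC2=O`: 148000 nM
- compound 2 `O=C(S[C@@]12CC[C@H](O)[C@@H]1C(=O)NC2=O)c1ccccc1Cl`: 127000 nM
- compound 3 `O=C(S[C@]12CC[C@H](O)[C@H]1C(=O)NC2=O)c1ccccc1Cl`: 178000 nM

In this assay compound 2 gives 127000 nM, which places it within the usual scatter of both compounds it can be compared with directly. Two measured steps show this: a 1.2-fold lower number from compound 1 to compound 2 (0.07 log units; within the scatter) and a 1.4-fold higher number from compound 2 to compound 3 (0.15 log units; within the scatter). The second of these is a change of shape only, given (the fact that compounds 2 and 3 differ only in the configuration as drawn), and it does not move the number beyond the scatter.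

The next structure is compound 4 `O=C(S[C@@]12CC[C@H](O)[C@@H]1C(=O)NC2=O)c1ccccc1`, which has hydrogen in place of chloro on an aromatic carbon, ortho to a large group: hydrogen in place of chloro on an aromatic carbon. Put another way, 2-chlorophenyl becomes phenyl.

Going by the values given here, the most useful guide is the first step, a 1.2-fold lower number from compound 1 to compound 2 (0.07 log units; within the scatter). There, a whole 2-chlorophenyl group took the place of methyl on a carbonyl carbon, yet the number stayed within the scatter. Compound 4 keeps the ring and loses only the chloro, so no step beyond the scatter is expected in this assay. The expected step is small: a 1.1-fold higher number from compound 2 to compound 4 (0.04 log units; within the scatter). For compound 4 the estimated value is 140000 nM, with an expected range of 80000 nM to 240000 nM.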

Compound 4, half-maximal inhibitory concentration: 72400 nM
Compound 4: middle estimate off by 1.9-fold (0.29 log units), on the high side; measured number below the stated range.
By their numbers in this assay, from the lowest: compounds 4, 2, 1 and 3 (each within the scatter of the next, the first and the last beyond it).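

Taking the chloro off the ring in this assay gives a step that stays within the scatter (a 1.8-fold lower number from compound 2 to compound 4 (0.24 log units; within the scatter)), so the number of compound 2 does not depend measurably on this one atom, and hydrogen serves about as well as chloro at this place on the ring. Compared with the methyl group of compound 1, however, the plain phenyl group gives a modest step that is the first one here to pass beyond the scatter (a 2.0-fold lower number from compound 1 to compound 4 (0.31 log units; beyond the scatter)), while the 2-chlorophenyl group on the same carbonyl carbon stayed within it (a 1.2-fold lower number from compound 1 to compound 2 (0.07 log units; within the scatter)). The information at hand explains neither of the two new steps.

The compounds shown leave open whether a methoxy group or a fluoro in place of the chloro would move the number any further, and whether a longer chain or an amine-bearing group in place of methyl on the carbonyl carbon would follow phenyl. They also leave open whether the phenyl group would give a different number on the configuration drawn for compound 3.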